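Swapping Nitro for Chloro on the Aryl Tail

This account rests on a few compounds, and the source may have more. Where it says the series, first, only, none or still open, it means among the compounds named here.

Measured so far in a functional assay on the whole organism (plasma, strain Wistar) with Rattus norvegicus as the target, with a stated time of 15 days, at a dose of 3 mg/kg by the oral route; a higher number here means a stronger effect of the compound at the dose given, a lower number a weaker effect:
- compound 1 `O=C1NC(=O)/C(=C/c2ccc(OCCSc3nnc(-c4ccccc4)[nH]3)cc2)S1`: 10.4%
- compound 2 `O=C1NC(=O)/C(=C/c2ccc(OCCSc3nnc(Cc4ccccc4)[nH]3)cc2)S1`: 18.3%
- compound 3 `O=C1NC(=O)/C(=C/c2ccc(OCCSc3nnc(-c4ccc([N+](=O)[O-])cc4)[nH]3)cc2)S1`: 11.9%

All three compounds share one core and differ only in the group carried on the triazole ring. The numbers of compound 3 and its two neighbours lie close together: the step of a number 1.5 percentage points higher from compound 1 to compound 3 (within the scatter) and the step of a number 6.4 percentage points lower from compound 2 to compound 3 (within the scatter) are both within the scatter, as is a number 7.9 percentage points higher from compound 1 to compound 2 (within the scatter), so none of the three can be called stronger or weaker than another.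

Compound 4 `O=C1NC(=O)/C(=C/c2ccc(OCCSc3nnc(-c4ccc(Cl)cc4)[nH]3)cc2)S1` is the next compound, and it differs from compound 3 in one place: chloro in place of nitro on an aromatic carbon. For the measured compounds named here, the only measured step that touches this position is a number 1.5 percentage points higher from compound 1 to compound 3 (within the scatter), which was within the scatter, and no measured compound carries a chloro group, so there is nothing to suggest a move beyond the scatter here. In this assay compound 4 is therefore expected to give about 12%, with a likely range from 4% to 20%. This estimate means a step of a number 0.1 percentage points higher from compound 3 to compound 4 (within the scatter), which is expected to stay within the scatter.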

Compound 4, a percentage reported as activity, at one dose (the size of the read-out at that dose, not a potency): 16%
Estimate against measurement, compound 4: 4 percentage points below; low and high end bracket the measured number.
By their numbers in this assay, from the lowest: compounds 1, 3, 4 and 2 (each within the scatter of the next).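

Chloro on the aromatic carbon that carried nitro in compound 3 gives a number 4.1 percentage points higher from compound 3 to compound 4 (within the scatter) in this assay and chloro in place of hydrogen gives a number 5.6 percentage points higher from compound 1 to compound 4 (within the scatter) in the same read-out. Exchanging benzyl for 4-chlorophenyl gives a number 2.3 percentage points lower from compound 2 to compound 4 (within the scatter) as well, so this new group still sets none of the four compounds apart from the others at the single dose tested. Nothing available explains why these different groups leave the read-out within the scatter.

Going by these compounds, whether an amine or a carboxylic acid on this aromatic carbon would move the number beyond the scatter remains open. On these data alone, it is also open whether a longer chain in place of benzyl would separate any compound from this group.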